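The source may hold more compounds than are shown below. What is called first, only, known or untested is meant among the compounds shown, and "the series" means these compounds.

Three compounds of the series have been run in a functional assay on OVCAR-3 cells (Homo sapiens) for inhibition, read by sulforhodamine B assay, with a stated time of 48 h, tested at 0.1 uM; on this read-out higher numbers stand for a weaker effect at the one concentration tested and lower numbers for a stronger effect. Compound 1 `O=C(Nc1cccc(-n2cc(-c3ccncc3)c(-c3cc(O)cc(Cl)c3)n2)c1)Nc1ccc(Cl)c(C(F)(F)F)c1` gives 95% in this assay. Compound 2 `O=C(Nc1cccc(-n2cc(-c3ccncc3)c(-c3cc(O)cc(Cl)c3)n2)c1)Nc1ccc(Cl)c(Cl)c1` gives 101% in this assay, and compound 3 `COc1cc(Cl)cc(-c2nn(-c3cccc(NC(=O)Nc4ccc(Cl)c(C(F)(F)F)c4)c3)cc2-c2ccncc2)c1` gives 99% in this assay. Compound 3 thus stands second highest of the three numbers; its nearest neighbour on the numbers is compound 2 and its furthest is compound 1, and both lie within the scatter of it. The two measured steps carry no movement beyond the scatter: a number 6 percentage points higher from compound 1 to compound 2 (within the scatter), and a number 4 percentage points higher from compound 1 to compound 3 (within the scatter).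

Compound 4 `COc1cc(Cl)cc(-c2nn(-c3cccc(NC(=O)Nc4ccc(Cl)c(Cl)c4)c3)cc2-c2ccncc2)c1` is not yet measured. It differs from compound 3 in one place: chloro in place of trifluoromethyl on an aromatic carbon. Going by the values given here, the only measured step that bears on this change is the one from compound 1 to compound 2, where the same exchange of groups on the same ring appears: a number 6 percentage points higher from compound 1 to compound 2 (within the scatter). Since that step stayed within the scatter, no step beyond the scatter is expected in this assay here either, and the expected step is a number 3 percentage points higher from compound 3 to compound 4 (within the scatter). Compound 4 is therefore estimated at 102% in this assay, with a range from 90% to 112%.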

Compound 4, a percentage reported as activity, at one concentration (the size of the read-out at that concentration, not a potency): 101%
Compound 4: middle estimate off by 1 percentage points, on the high side, within the range that was stated.
By their numbers in this assay, from the lowest: compounds 1, 3, 2 and 4 (each within the scatter of the next).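

The exchange of trifluoromethyl for chloro has now been read on a second core, and in this assay it gives a number 2 percentage points higher from compound 3 to compound 4 (within the scatter) on the core that carries the methyl on oxygen, so the earlier step was not particular to the core of compound 1, and the two readings agree within the scatter: the same change on two cores in this assay, a number 6 percentage points higher (within the scatter) from compound 1 to compound 2 and a number 2 percentage points higher (within the scatter) from compound 3 to compound 4, 4 percentage points apart, within the scatter of two such steps.

Methyl in place of hydrogen on the aromatic oxygen has also been read a second time, now with the 3,4-dichlorophenyl group in place of the 4-chloro-3-(trifluoromethyl)phenyl group, and it gives no change at the digits printed from compound 2 to compound 4 (within the scatter) as the step: the same change on two cores in this assay, a number 4 percentage points higher (within the scatter) from compound 1 to compound 3 and no change at the digits printed (within the scatter) from compound 2 to compound 4, 4 percentage points apart, within the scatter of two such steps.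

Each of the two changes has thus been read in the presence and in the absence of the other, and in all four compounds neither moves the read-out beyond the scatter at the one concentration tested.

Going by these compounds, whether a group of another kind at this position of the aromatic ring, such as an amine, a carboxylic acid or a longer chain, would move the number beyond the scatter remains open. Also open, on these data alone, is whether these two changes stay as silent at other concentrations, since a reading at one concentration gives no potency.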